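A few compounds are considered here, and "the series" means these few. Any claim that something is new, unique, unknown or untested is made for them only; others in the source may bear on it.

In an assay on HEK293 cells for displacement of a labelled ligand from 5-hydroxytryptamine receptor 6 (Homo sapiens) (on this read-out higher numbers stand for weaker inhibition and lower numbers for stronger inhibition), compound 1 `O=C1c2ccccc2S(=O)(=O)N1CCCCCCN1CCN(c2cccc(Cl)c2Cl)CC1` gives 72 nM, the lower of the two numbers recorded so far. For the measured compounds named here, the only other measured compound, compound 2 `O=C1c2ccccc2S(=O)(=O)N1CCCCCN1CCN(c2ncccn2)CC1`, gives 7100 nM in this assay, a gap from compound 1 that lies well beyond the usual scatter. Compound 3 `O=C1c2ccccc2S(=O)(=O)N1CCCCCCN1CCN(c2ncccn2)CC1` has not yet been measured in this assay. It differs from compound 1 in one place: pyrimidin-2-yl in place of 2,3-dichlorophenyl on an amine nitrogen in a ring. Compound 3 thus carries the same pyrimidin-2-yl group that compound 2 carries, while keeping the chain of compound 1. Since compound 2 with the pyrimidin-2-yl group gives 7100 nM, the step from compound 1 is expected to be large and toward a weaker result, a 42-fold higher number from compound 1 to compound 3 (1.62 log units; beyond the scatter). Compound 3 is therefore estimated to give 3000 nM in this assay, with a likely range from 800 nM to 12000 nM.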

Compound 3, inhibition constant: 5710 nM
The estimate for compound 3 lay 1.9-fold (0.28 log units) below the measured number, within the range that was stated.
By their numbers in this assay, from the lowest: compound 1; then compounds 3 and 2 (each within the scatter of the next).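

In this assay, replacing 2,3-dichlorophenyl with pyrimidin-2-yl on an amine nitrogen in a ring, with the chain unchanged, can now be read as a single change: a 79-fold higher number from compound 1 to compound 3 (1.90 log units; beyond the scatter), a large step beyond the scatter. The earlier gap could not be assigned to this position alone, since the two earlier compounds also differ in their chains. With pyrimidin-2-yl in place, compound 3 at 5710 nM and compound 2 at 7100 nM lie within the scatter of each other, so the chain difference shows no separable effect in this pair. No measured evidence accounts for the size of the step. Still open, going by these compounds, is how a plain phenyl, a 2-chlorophenyl or a pyridin-2-yl group on the same nitrogen would read, which would show whether the chlorine atoms or the ring nitrogens matter more.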